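The source may hold more compounds than are shown below. What is called first, only, known or untested is meant among the compounds shown, and "the series" means these compounds.

Working notes on the cytotoxicity series. In an ADME assay on HEK293 cells (Homo sapiens) for cytotoxicity, with a stated time of 72 h (a lower number here means that less compound is needed, a higher number that more compound is needed for the effect), compound 1 `C=C[C@@](C)(/C=C/c1ccc(OCc2ccccc2)cc1)CCC=C(C)C` gives only a limit, > 36600 nM. Compound 2 `C=C[C@@](C)(/C=C/c1ccc(O)c(/C=C/C(=O)OCc2ccccc2)c1)CCC=C(C)C` likewise gives only a limit, > 36600 nM. Compound 3 `C=C[C@@](C)(/C=C/c1ccc(O)c(/C=C/C(=O)NCc2ccc(C(F)(F)F)cc2)c1)CCC=C(C)C` also gives only a limit, > 36600 nM. Compound 1 therefore stands at the limit of > 36600 nM in this assay, at which 3 of the 3 values shown sit, with no number that would separate it from the other two. Compound 4 `C=C[C@@](C)(/C=C/c1ccc(Nc2ccc(Cl)c(Cl)c2)cc1)CCC=C(C)C` is not yet measured. The change from compound 1 is (3,4-dichlorophenyl)amino in place of benzyloxy on an aromatic carbon. Within the data shown here, with every value so far a limit, no step beyond the scatter is expected in this assay. Compound 4 is expected to give about 50000 nM, with a range of 20000 nM to 150000 nM. The step that the limit leaves unreadable from compound 1 to compound 4 is expected to be near zero, and a further limit rather than a number is the likelier outcome.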

Compound 4, half-maximal effective concentration: > 36600 nM
Compound 4 gave a limit, no number (the forecaster's own chance of this, stated with the estimate: 80%); the middle value is on the limit's open side.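

No step can be read from compound 1 to compound 4, since both give only a limit in this assay: the limit of > 36600 nM in this assay, at which 4 of the 4 values shown sit.

The compounds shown leave open how (3,4-dichlorophenyl)amino and benzyloxy compare in this assay, and whether any structure here reaches a measurable value.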